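The compounds below may be only part of what the source reports. "The series", "measured", "known", "first", "only" and "open" are said of these compounds alone.

Compound 1 `CCCCCCCCCCCCCCOc1cccc(N2C(N)=NC(N)=NC2(C)C)c1` is the most potent of the three compounds measured in a functional assay on L5178Y cells (Mus musculus); a higher number here means a more potent compound, by a factor of ten per unit of this negative logarithm, a lower number a less potent compound: compound 1 gives 6.49. Compound 2 `COc1cccc(OCc2cccc(N3C(N)=NC(N)=NC3(C)C)c2)c1` carries a methoxybenzyloxy group on the shared core, and in this assay compound 2 gives 5.36. Compound 3 `CC(C)c1cccc(OCc2cccc(N3C(N)=NC(N)=NC3(C)C)c2)c1` differs from it only by an isopropyl in place of methoxy on an aromatic carbon; compound 3 gives 5.87, a change of a number 0.51 log units higher from compound 2 to compound 3 (beyond the scatter).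

Compound 4 `CCCCOc1cccc(N2C(N)=NC(N)=NC2(C)C)c1` is the next compound to be tested. It is compound 1 with a much shorter chain: hydrogen in place of decyl on a saturated chain carbon, four bonds along the chain from an oxygen on an aromatic ring

Within the data shown here, no measured pair shows what removing a long stretch of chain does; the only measured step swaps one small group for another on an aromatic ring. What is known is that compound 1, with its long chain, sits well above compounds 2 and 3 in this assay. The expectation is therefore that the shortened chain costs potency, a step of a number 1.49 log units lower from compound 1 to compound 4 (beyond the scatter) in this assay, so that compound 4 is estimated at 5, within a range from 4.2 to 5.8.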

Compound 4, logarithm of the reciprocal of the active concentration, log(1/C): 5.95
Compound 4: middle estimate off by 0.95 log units, on the low side; measured number outside the range, above it.
By their numbers in this assay, from the lowest: compound 2; then compounds 3 and 4 (each within the scatter of the next); then compound 1.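

In this assay, among these compounds, hydrogen in place of decyl gives a step of a number 0.54 log units lower from compound 1 to compound 4 (beyond the scatter) and marks the first measured change at this chain position. The step shows that the decyl stretch does add potency, but that the step is modest for the loss of so many carbon atoms, and compound 4 with its short chain still gives 5.95 in this assay. No measurement here explains why the decyl stretch contributes this amount.

A hexyl or an octyl chain at this position would show whether potency rises steadily with chain length or changes abruptly at some length. As far as these compounds go, it also remains open whether an amine or a carboxylic acid at the end of the chain would keep, raise or lower the value of compound 4.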